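The compounds below may be only part of what the source reports. "The series", "measured", "known", "first", "only" and "open" are said of these compounds alone.

In an ADME assay on WI-38 cells (Homo sapiens) for cytotoxicity, read by MTT assay, with a stated time of 72 h (on this read-out lower numbers stand for stronger inhibition and higher numbers for weaker inhibition), compound 1 `O=C(CCc1cccc2c1B(O)OC2)Nc1ccc(Cl)cc1` reads > 100000 nM, which is a limit of the assay and not a number. For the measured compounds named here, compound 2 `CC(C)(C)c1ccc(NC(=O)CCc2cccc3c2B(O)OC3)cc1` gives 55000 nM, the only actual number so far. Compound 3 `CC(C)(C)OC(=O)NCc1ccc(NC(=O)CCc2cccc3c2B(O)OC3)cc1` carries ((tert-butoxycarbonyl)amino)methyl in place of tert-butyl on an aromatic carbon, para to a large group: ((tert-butoxycarbonyl)amino)methyl in place of tert-butyl on an aromatic carbon. Going by the values given here, the one measured step at this place is an at least 1.8-fold lower number from compound 1 to compound 2 (0.25 log units; that floor lies within the scatter), so it sets no clear size for a change here. The expected step is therefore small, a 1.1-fold higher number from compound 2 to compound 3 (0.04 log units; within the scatter), with no shift beyond the scatter expected in this assay. For compound 3 the estimated value is 60000 nM, with a range from 25000 nM to 100000 nM.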

Compound 3, half-maximal inhibitory concentration: 4800 nM
Estimate against measurement, compound 3: 13-fold (1.10 log units) above, outside the stated range (below it).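

At this position the read-out clearly responds to the group carried, which the earlier step could not show: in this assay, ((tert-butoxycarbonyl)amino)methyl in place of tert-butyl gives an 11-fold lower number from compound 2 to compound 3 (1.06 log units; beyond the scatter). The same group in place of chloro gives an at least 20-fold lower number from compound 1 to compound 3 (1.31 log units; beyond the scatter). The size of that step is only a floor, set by the limit of compound 1: the limit of > 100000 nM in this assay, at which 1 of the 3 values shown sits.

Which part of the larger group carries this stronger effect on the cells remains open. A free aminomethyl group or a plain amine at this position would help to separate the parts.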